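The source may hold more compounds than are shown below. What is called first, only, known or untested is meant among the compounds shown, and "the series" means these compounds.

Three compounds measured in a toxicity assay on THP-1 cells (Homo sapiens) for inhibition (on this read-out lower numbers stand for higher toxicity in this test and higher numbers for lower toxicity in this test), set the scene. Compound 1 `COc1ccc(-c2cnc(NC(=O)c3ccc(F)cc3)n2Cc2ccccc2)cc1` reaches only a limit of the assay in this assay, > 100000 nM. Compound 3 `O=C(Nc1ncc(-c2ccccc2)o1)c1ccc(Cl)cc1` gives 10000 nM in this assay. Compound 2 `COc1ccc(-c2cnc(NC(=O)c3ccno3)n2C)cc1` likewise reaches only a limit of the assay, > 100000 nM. Compound 2 thus stands at the boundary of what this assay reports, and the figure for it is a limit rather than a number; the limit of > 100000 nM in this assay, at which 2 of the 3 values shown sit, marks that boundary. Going by the values given here, no pair among the measured compounds differs in a single place, so no measured step exists to lean on. Compound 4 `COc1ccc(-c2cnc(NC(=O)C3CCCCC3)n2C)cc1` is the untested compound, differing from compound 2 in one place: cyclohexyl in place of 1,2-oxazol-5-yl on a carbonyl carbon. Among the compounds with values here, with no measured step to guide the change, the expectation for compound 4 rests on where compound 2 stands, at a limit. Compound 4 is expected to remain close to that limit, with an estimated step of a number no higher from compound 2 to compound 4 (the limit leaves the size open), which is no step beyond the scatter. Compound 4 is therefore estimated at 100000 nM in this assay, expected to fall between 30000 nM and 300000 nM.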

Compound 4, half-maximal cytotoxic concentration: > 100000 nM
Compound 4 ended at the assay's limit; the forecaster's own chance of this, stated with the estimate: 60%; the middle value lies on the limit itself.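

Compound 2 and compound 4 both sit at a limit of this assay, so no step between them can be read: the limit of > 100000 nM in this assay, at which 3 of the 4 values shown sit.

The compounds shown leave open whether cyclohexyl in place of 1,2-oxazol-5-yl on a carbonyl carbon changes the half-maximal cytotoxic concentration at all.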